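The compounds below may be only part of what the source reports. "The series", "measured", "known", "first", "only" and "open" are said of these compounds alone.

Among the measured compounds shown here, in a physicochemical assay for lipophilicity, at pH 7.4 (on this read-out lower numbers stand for lower lipophilicity and higher numbers for higher lipophilicity), compound 1 `Cc1cc(C)c(CN2CCc3c(Cl)cc([C@H](CO)[C@H]4CCOC4)c(Cl)c3C2=O)c(=O)[nH]1` gives 2 and compound 2 `COc1cc(C)[nH]c(=O)c1CN1CCc2c(Cl)cc(-c3c(C)noc3C)c(Cl)c2C1=O` gives 2.7 as the only other measured number. Compound 1 therefore stands lower of the two, by a gap beyond the usual scatter of such measurements. Compound 3 `Cc1cc(C)c(CN2CCc3c(Cl)cc([C@@H](C)CO)c(Cl)c3C2=O)c(=O)[nH]1` has not been measured yet. It keeps the core of compound 1 but carries methyl in place of oxolan-3-yl on a saturated chain carbon bound to an aromatic carbon and a saturated chain carbon. For the measured compounds named here, no two measured compounds differ in one place only, so no measured step can guide this one and the expectation stays rough. In this assay no shift beyond the scatter is expected. The estimated step is a number 0.10 log units lower from compound 1 to compound 3 (within the scatter) in size and direction. Compound 3 is estimated at 1.9 with a likely range from 1.5 to 2.3 around that figure.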

Compound 3, distribution coefficient: 2.5
Compound 3: middle estimate off by 0.60 log units, on the low side; the whole stated range lies below it.
By their numbers in this assay, from the lowest: compound 1; then compounds 3 and 2 (each within the scatter of the next).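

Among the compounds shown here, compound 1 and compound 3 are the first pair here that differ in one place only, so a change on the saturated chain carbon bound to an aromatic carbon and a saturated chain carbon can now be read directly. In this assay, putting methyl in place of oxolan-3-yl gives a number 0.50 log units higher from compound 1 to compound 3 (beyond the scatter) and so shows that this position is not indifferent to which group it carries. Nothing measured here explains the shift.

On these data alone, with a single pair, it stays open whether the step follows the loss of the ring as a whole or of its oxygen alone. A cyclopentyl group on the same carbon would keep the ring without the oxygen, and a methoxymethyl chain would keep the oxygen without the ring.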